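Methoxy to Bromo on a Shared Aryl Ring: Two Pairs

A few compounds are considered here, and "the series" means these few. Any claim that something is new, unique, unknown or untested is made for them only; others in the source may bear on it.

Compound 1 `COc1ccc(-c2cc(CN(c3nc4ccc(F)cc4s3)c3nc4ccc(OC)cc4s3)on2)cc1` gives 32400 nM in a functional assay on MCF7 cells (Homo sapiens) for antiproliferative activity, read by MTT assay; a lower number here means a stronger inhibitor, a higher number a weaker inhibitor. Compound 2 `COc1ccc2nc(N(Cc3cc(-c4ccc(Br)cc4)no3)c3nc4ccc(F)cc4s3)sc2c1` carries bromo in place of methoxy on an aromatic carbon and gives 41200 nM; the step of a 1.3-fold higher number from compound 1 to compound 2 (0.10 log units; within the scatter) is small. Compound 3 `COc1ccc(-c2cc(CN(c3ncccn3)c3nc4ccccc4s3)on2)cc1` shares the same change with the two above only in part, and the difference between its core and the core of compound 1 is not broken down here; compound 3 gives 30700 nM in this assay. Compound 4 `Brc1ccc(-c2cc(CN(c3ncccn3)c3nc4ccccc4s3)on2)cc1`, not yet measured, differs from compound 3 by bromo in place of methoxy on an aromatic carbon, the same change as from compound 1 to compound 2, at the same place. Because the earlier step of a 1.3-fold higher number from compound 1 to compound 2 (0.10 log units; within the scatter) stayed within the scatter, a step of similar size is expected, a 1.2-fold higher number from compound 3 to compound 4 (0.09 log units; within the scatter). Compound 4 is therefore estimated at 38000 nM, between 19000 nM and 76000 nM.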

Compound 4, half-maximal inhibitory concentration: 21100 nM
The estimate for compound 4 lay 1.8-fold (0.26 log units) above the measured number; the range from low to high includes it.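

Replacing methoxy with bromo on the core of compound 3 gives a 1.5-fold lower number from compound 3 to compound 4 (0.16 log units; within the scatter) in this assay, and this step does not differ from the earlier one beyond what repeated measurements allow: the same change on two cores in this assay, a 1.3-fold higher number (0.10 log units; within the scatter) from compound 1 to compound 2 and a 1.5-fold lower number (0.16 log units; within the scatter) from compound 3 to compound 4, 1.9-fold (0.27 log units) apart, within the scatter of two such steps. On these two cores, then, the change from 4-methoxyphenyl to 4-bromophenyl stays within the scatter, and the opposite directions of the two steps carry no weight. This does not show that the change would behave the same way on every core in the series, as only two pairs are shown.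

The compounds shown leave open what other groups at this place would do, such as an amine, a carboxylic acid or a longer alkoxy chain. They also leave open whether any such group would shift the number beyond the scatter.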